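Furanopyridine to thienopyridine swap at the ether oxygen

The source may report more compounds than this note shows. Statements on the series, on what has been measured and on what is new or still open speak of the compounds shown alone.

Two members of the series are measured. Compound 1 `Cc1ncc2nccn2c1-c1ccc(Oc2nccc3occc23)cc1C(F)(F)F` gives 7900 nM in an assay on cells for displacement of a labelled ligand from 5-hydroxytryptamine receptor 6 (Homo sapiens), read by scintillation counting, with a stated time of 90 min; a lower number here means a stronger inhibitor, a higher number a weaker inhibitor. Going by the values given here, compound 2 `FC(F)(F)c1cc(Oc2nccc3occc23)ccc1-c1cccc2nccn12` gives 6900 nM in this assay, and the single step so far, a 1.1-fold lower number from compound 1 to compound 2 (0.06 log units; within the scatter), changes the bicyclic group on the aromatic carbon at the other end of the molecule and is within the scatter; compound 2 therefore stands level with compound 1 on the numbers available.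

Compound 3 `FC(F)(F)c1cc(Oc2nccc3ccsc23)ccc1-c1cccc2nccn12` is not yet measured. It differs from compound 2 by a group of 9 heavy atoms (7 carbon, 1 nitrogen, 1 sulfur; one five-membered aromatic ring with 1 hetero atom, one six-membered aromatic ring with 1 hetero atom) in place of a group of 9 heavy atoms (7 carbon, 1 nitrogen, 1 oxygen; one five-membered aromatic ring with 1 hetero atom, one six-membered aromatic ring with 1 hetero atom), on an oxygen on an aromatic ring. Among the compounds with values here, no measured step touches this position, so nothing bears directly on the change; the one step known elsewhere in the molecule was within the scatter. A step in this assay of no more than the scatter is expected, no change at the digits printed from compound 2 to compound 3 (within the scatter), in either direction. Compound 3 is estimated at 6900 nM, with a range from 2500 nM to 19000 nM.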

Compound 3, inhibition constant: 7200 nM
Estimate against measurement, compound 3: 1.0-fold (0.02 log units) below; measured number inside the range.
By their numbers in this assay, from the lowest: compounds 2, 3 and 1 (each within the scatter of the next).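

At the group on an oxygen on an aromatic ring, the bicyclic group holding sulfur in place of the one holding oxygen gives a 1.0-fold higher number from compound 2 to compound 3 (0.02 log units; within the scatter) in this assay, so this end of the molecule now has a step of its own, and it lies within the scatter. The two groups match in heavy-atom count, ring types and counted hydrogen-bond donors and acceptors, and this exchange of oxygen for sulfur leaves the number level in this series. No measurement on hand gives a reason for this result.

Open, going by these compounds, is whether a less closely matched group at this place, such as a plain phenyl ring or a bicyclic group carrying an amine or a carboxylic acid, would move the number beyond the scatter. Also open is what replacing the trifluoromethyl group would do, as no step shown touches it.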